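The compounds below may be only part of what the source reports. "The series", "measured", "known", "first", "only" and "open" are said of these compounds alone.

Compound 1 `Cc1n[nH]c(C)c1-c1cc2c(s1)C(=O)NC(C)(C)N2C`: 2100 nM
Compound 2 `CCC1(C)NC(=O)c2sc(-c3ccncc3)cc2N1`: 36 nM
Compound 3 `Cc1c(-c2cn[nH]c2)sc2c1N(C)C(C)(C)NC2=O`: 44 nM

In an assay for inhibition of Rho-associated protein kinase 1 (Homo sapiens), read by TR-FRET, with stated times of 5 min and 2 h (on this read-out higher numbers stand for weaker inhibition and lower numbers for stronger inhibition), compound 2 gives 36 nM, the lowest of the three numbers shown, though compound 3, with 44 nM, lies within the scatter of it; compound 1 gives 2100 nM, which lies beyond the scatter. Compound 4 `CC1(CC(F)(F)F)NC(=O)c2sc(-c3ccncc3)cc2N1` differs from compound 2 by trifluoromethyl in place of methyl on a saturated chain carbon bound to a saturated ring carbon. Among the compounds with values here, no measured pair carries this change, so its effect in this assay is not known from the measured compounds. The expected effect is a small rise in the number, within the scatter, a 1.7-fold higher number from compound 2 to compound 4 (0.22 log units; within the scatter). Compound 4 is accordingly estimated at 60 nM, in a range from 15 nM to 250 nM.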

Compound 4, half-maximal inhibitory concentration: 31 nM
Estimate against measurement, compound 4: 1.9-fold (0.29 log units) above; the range from low to high includes it.
By their numbers in this assay, from the lowest: compounds 4, 2 and 3 (each within the scatter of the next); then compound 1.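

Trifluoromethyl in place of methyl on a saturated chain carbon bound to a saturated ring carbon leaves the number in this assay within the scatter (a 1.2-fold lower number from compound 2 to compound 4 (0.06 log units; within the scatter)). Within the data shown here, this gives the first measured pair at this position, which therefore accepts this change without a shift beyond the scatter. Nothing measured here accounts for that result.

The compounds shown leave open whether a longer chain, an amine or a carboxylic acid at this place would be accepted as well. They also leave open whether the same change would behave alike on another core.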